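The source may report more compounds than this note shows. Statements on the series, on what has been measured and on what is new or still open speak of the compounds shown alone.

Working notes on the series. In a functional assay on A549 cells (Homo sapiens) for cytotoxicity, with a stated time of 48 h (a lower number here means a stronger inhibitor, a higher number a weaker inhibitor), compound 1 (`Cc1ccc2oc(/C=C/[S+](C)[O-])cc(=O)c2c1`) gives 1700 nM and compound 2 (`CCC(=O)Oc1ccc2oc(/C=C/[S+](C)[O-])cc(=O)c2c1`) gives 2400 nM. Among the measured compounds shown here, these are the only two numbers so far, and they lie within the scatter of each other, so compound 2 cannot be separated from compound 1. The next structure is compound 3 (`COc1ccc2oc(/C=C/[S+](C)[O-])cc(=O)c2c1`), which differs from compound 2 as follows: methyl in place of propanoyl on an oxygen on an aromatic ring. Put plainly, propanoyloxy gives way to methoxy. For the measured compounds named here, one measured step bears on this change: a 1.4-fold higher number from compound 1 to compound 2 (0.15 log units; within the scatter). It also involves the propanoyloxy group, although there the exchange is with methyl on an aromatic carbon. Methoxy itself has no measured value yet, and a single step is thin evidence. With only a 1.4-fold higher number from compound 1 to compound 2 (0.15 log units; within the scatter) to go on, no step beyond the scatter is expected in this assay, in either direction. The expected change is a 1.2-fold lower number from compound 2 to compound 3 (0.08 log units; within the scatter). For compound 3 the estimated value is 2000 nM, with an expected range of 900 nM to 4500 nM.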

Compound 3, half-maximal inhibitory concentration: 1600 nM
The estimate for compound 3 lay 1.3-fold (0.10 log units) above the measured number; measured number inside the range.
By their numbers in this assay, from the lowest: compounds 3, 1 and 2 (each within the scatter of the next).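

In this assay the change from propanoyl to methyl on an oxygen on an aromatic ring gives a 1.5-fold lower number from compound 2 to compound 3 (0.18 log units; within the scatter) and so removes three of the four heavy atoms of the leaving group, along with its double bond and its hydrogen-bond acceptor, without a step beyond the scatter. Among the compounds shown here, the exchange of methyl for methoxy at the same place, a comparison the earlier compounds could not offer, gives a 1.1-fold lower number from compound 1 to compound 3 (0.03 log units; within the scatter) and is likewise within the scatter, so methyl, methoxy and propanoyloxy cannot be separated from one another at this position in these three compounds. No evidence is available on what lies behind these numbers.

The three groups leave open whether any group at this position moves the number beyond the scatter, for example an amine, a carboxylic acid or a longer chain such as butoxy. Also open, as far as these compounds go, is whether the same lack of separation would hold with a change elsewhere on the shared core, since all three compounds carry the same remainder of the structure.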